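Removing the Phenoxy Group from Compound 3

The source may hold more compounds than are shown below. What is called first, only, known or untested is meant among the compounds shown, and "the series" means these compounds.

Three measured compounds share one amide core. Compound 1 `CCCCOc1cccc(C(=O)Nc2nn[nH]n2)n1` gives 8% in a functional assay on the whole organism for inhibition, with Rattus norvegicus as the target, at a dose of 10 mg/kg by the oral route; on this read-out lower numbers stand for a weaker effect and higher numbers for a stronger effect at the one dose given; compound 2 `Cc1ccc(C(=O)Nc2nn[nH]n2)nc1` gives 42% in this assay; compound 3 `O=C(Nc1nn[nH]n1)c1cccc(Oc2ccccc2)n1` gives 0% in this assay. Compound 3 thus has the lowest number of the three, with compound 1 within the scatter of it and compound 2 beyond it. Compound 4 `O=C(Nc1nn[nH]n1)c1ccccn1` differs from compound 3 by hydrogen in place of phenoxy on an aromatic carbon. Within the data shown here, the only measured step touching that group is a number 8 percentage points lower from compound 1 to compound 3 (within the scatter), which shows that exchanging one group on the oxygen for another changed little. Among the measured compounds shown here, no measured step removes the group entirely, and compound 2, carrying only a methyl group, gives a higher number. The step is therefore expected to be a number 20 percentage points higher from compound 3 to compound 4 (beyond the scatter), a modest rise. Compound 4 is estimated at 20%, between 0% and 45%.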

Compound 4, a percentage reported as inhibition, in the whole organism at one dose (the size of the read-out at that dose, not a potency): 35%
Compound 4: the middle estimate sits 15 percentage points below what was measured; low and high end bracket the measured number.
By their numbers in this assay, from the lowest: compounds 3 and 1 (each within the scatter of the next); then compounds 4 and 2 (each within the scatter of the next).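

In this assay hydrogen in place of phenoxy gives a number 35 percentage points higher from compound 3 to compound 4 (beyond the scatter) and hydrogen in place of butoxy gives a number 27 percentage points higher from compound 1 to compound 4 (beyond the scatter) on the same carbon next to the ring nitrogen, so neither group on oxygen is needed there for a number of this size. Hydrogen in place of methyl on an aromatic carbon gives a number 7 percentage points lower from compound 2 to compound 4 (within the scatter) and leaves those two compounds indistinguishable here. No measured evidence accounts for these steps.

Still open, as far as these compounds go, is whether a smaller group on this carbon, such as methoxy, an amine or a chlorine atom, would keep the number seen with hydrogen or lower it.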